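A few compounds are considered here, and "the series" means these few. Any claim that something is new, unique, unknown or untested is made for them only; others in the source may bear on it.

Compound 1 `CCNC(=O)Nc1ccc(S(=O)(=O)Oc2ccccc2C)cc1` and compound 2 `CCNC(=O)Nc1ccc(S(=O)(=O)Oc2ccccc2CC)cc1` differ by a single change, (methyl in place of hydrogen on a saturated chain carbon bound to an aromatic carbon). In a functional assay on HT-29 cells (Homo sapiens) for cytotoxicity, read by sulforhodamine B assay, with a stated time of 48 h (a lower number here means a stronger inhibitor, a higher number a weaker inhibitor), compound 1 gives 12000 nM. Compound 2 gives 12000 nM. The step of no change at the digits printed from compound 1 to compound 2 (within the scatter) is thus flat.

Compound 3 `CCNC(=O)Nc1cccc(S(=O)(=O)Nc2ccccc2CC)c1` is built on another core; the difference between the core of compound 1 and the core of compound 3 is not broken down here. In this assay compound 3 gives 15000 nM, a number that sits within the scatter of both compound 1 and compound 2, so no order among the three can be read from these data.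

Compound 4 `CCCc1ccccc1NS(=O)(=O)c1cccc(NC(=O)NCC)c1` has not yet been measured. It differs from compound 3 by methyl in place of hydrogen on a saturated chain carbon, two bonds along the chain from an aromatic carbon. Among the compounds with values here, this is the same kind of change as the one between compound 1 and compound 2, though not the same: there the entering methyl sits on a saturated chain carbon bound to an aromatic carbon, whereas here it sits on a saturated chain carbon two bonds along the chain from an aromatic carbon, so that an ethyl becomes a propyl rather than a methyl becoming an ethyl.

Within the data shown here, the only precedent is the flat step no change at the digits printed from compound 1 to compound 2 (within the scatter), and on that basis the step of no change at the digits printed from compound 3 to compound 4 (within the scatter) is expected to be small. Compound 4 is estimated at 15000 nM. Its expected range runs from 6000 nM to 35000 nM.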

Compound 4, half-maximal inhibitory concentration: 41000 nM
Compound 4: the middle estimate sits 2.7-fold (0.44 log units) below what was measured; the measured number lies above the stated range.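

In this assay, the methyl that turns the ethyl of compound 3 into a propyl gives a 2.7-fold higher number from compound 3 to compound 4 (0.44 log units; beyond the scatter), a modest step, whereas the methyl that turns a methyl into an ethyl on the core of compound 1 gives no change at the digits printed from compound 1 to compound 2 (within the scatter), so a flat result on one core did not carry over to the other: the same change on two cores in this assay, no change at the digits printed (within the scatter) from compound 1 to compound 2 and a 2.7-fold higher number (0.44 log units; beyond the scatter) from compound 3 to compound 4, 2.7-fold (0.44 log units) apart, beyond the scatter of two such steps

This does not show that the core alone sets the size of the step, since the entering methyl also sits in a different place in the two pairs, on a saturated chain carbon bound to an aromatic carbon in the first and on a saturated chain carbon two bonds along the chain from an aromatic carbon in the second. With a single pair on each core, the core and the place of the methyl cannot be told apart, and nothing here shows how the change would behave on any further core.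

The compounds shown leave open whether a propyl on the core of compound 1 would follow the step seen on the core of compound 3. They also leave open whether a longer chain, or a chain ending in an amine or a carboxylic acid, would continue that step.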